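Adding a nitro group to the benzyl ring of compound 2

The source may report more compounds than this note shows. Statements on the series, on what has been measured and on what is new or still open speak of the compounds shown alone.

- compound 1 `CN(C)c1ccc(NCc2cncn2Cc2ccc(-c3ccccc3)cc2)cc1-c1ccccc1`: limit, > 1000 nM
- compound 2 `COC(=O)c1ccc(NCc2cncn2Cc2ccccc2)cc1-c1ccccc1`: limit, > 1000 nM

In a toxicity assay on NIH3T3 cells (Mus musculus) for cytotoxicity, read by resazurin assay (on this read-out lower numbers stand for an effect already at smaller amounts and higher numbers for an effect only at larger amounts of compound), compound 2 gives > 1000 nM as a limit of the assay, not a number. Among the measured compounds shown here, its standing is the limit of > 1000 nM in this assay, at which 2 of the 2 values shown sit, and no measured pair shows the effect of a single change. Compound 3 `COC(=O)c1ccc(NCc2cncn2Cc2ccc([N+](=O)[O-])cc2)cc1-c1ccccc1` carries nitro in place of hydrogen on an aromatic carbon on the benzyl ring, turning benzyl to 4-nitrobenzyl. The expected change, a step that the limit leaves unreadable from compound 2 to compound 3, stays within the usual scatter, with no direction expected. For compound 3 the estimated value is 1500 nM, with an expected range from 500 nM to 5000 nM and a good chance of another limit.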

Compound 3, half-maximal effective concentration: > 10000 nM
Compound 3: only a limit was reported; the forecaster's own chance of this, stated with the estimate: 80%; middle value at least 6.6-fold (0.82 log units) away from the limit.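

Compound 2 and compound 3 are each reported only as a limit in this assay, so the step between them cannot be read. Going by these compounds, whether 4-nitrobenzyl in place of benzyl shifts cytotoxicity at all, and in which direction, stays open.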